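Naphthalen-1-yl sulfonate ester tested for growth inhibition

This account rests on a few compounds, and the source may have more. Where it says the series, first, only, none or still open, it means among the compounds named here.

Compound 1 `O=C(O)CCCCCCC(=O)Nc1ccc(C2=C(c3ccc(O)cc3)C3CC(S(=O)(=O)Oc4ccc(C(F)(F)F)cc4)C2O3)cc1` gives 77000 nM in a functional assay on DU-145 cells (Homo sapiens) for inhibition, read by MTT assay, with a stated time of 72 h; on this read-out higher numbers stand for weaker inhibition and lower numbers for stronger inhibition. Compound 2 `O=C(O)CCCCCCC(=O)Nc1ccc(C2=C(c3ccc(O)cc3)C3CC(S(=O)(=O)Oc4ccccc4C(F)(F)F)C2O3)cc1` reaches only the limit of this assay, > 100000 nM. Compound 3 `O=C(O)CCCCCCC(=O)Nc1ccc(C2=C(c3ccc(O)cc3)C3CC(S(=O)(=O)Oc4ccc(F)cc4)C2O3)cc1` likewise reaches only the limit, > 100000 nM. So compound 3 stands at the top end of what this assay can report, together with one other compound, as noted by the limit of > 100000 nM in this assay, at which 2 of the 3 values shown sit.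

Compound 4 `O=C(O)CCCCCCC(=O)Nc1ccc(C2=C(c3ccc(O)cc3)C3CC(S(=O)(=O)Oc4cccc5ccccc45)C2O3)cc1` differs from compound 3 in one place: naphthalen-1-yl in place of 4-fluorophenyl on an oxygen.

Going by the values given here, two measured steps start from the one numbered value: an at least 1.2-fold higher number from compound 1 to compound 2 (0.11 log units; that floor lies within the scatter) and an at least 1.2-fold higher number from compound 1 to compound 3 (0.11 log units; that floor lies within the scatter). Both lead from the number of compound 1 up to the limit, so only their floors are known. The step that connects the two limits, a step that the two limits leave unreadable from compound 2 to compound 3, cannot be sized at all. None of these steps carries a naphthalen-1-yl group, so they bear on the change to compound 4 only by showing that all three sulfonate esters in this set sit at or near the limit.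

On that basis compound 4 is expected to stay in the same weak region, with an estimated 90000 nM and a likely range from 40000 nM to 200000 nM. The estimated step is an at least 1.1-fold lower number from compound 3 to compound 4 (0.04 log units; that floor lies within the scatter), which is expected to lie within the scatter, and a report of a limit rather than a number is considered likely.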

Compound 4, half-maximal inhibitory concentration: 48600 nM
Compound 4: middle estimate off by 1.9-fold (0.27 log units), on the high side; measured number inside the range.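

Going by these compounds alone, at this position, the oxygen whose other neighbour is the sulfonyl sulfur, naphthalen-1-yl gives the first changes in this assay that reach beyond the scatter: an at least 2.0-fold lower number from compound 3 to compound 4 (0.31 log units; beyond the scatter) and an at least 2.0-fold lower number from compound 2 to compound 4 (0.31 log units; beyond the scatter). On these data alone, both are floors rather than full sizes, so the true distance from compound 2 or compound 3 to compound 4 stays unknown, and the limit behind them is a shared one: the limit of > 100000 nM in this assay, at which 2 of the 4 values shown sit. The remaining step, a 1.6-fold lower number from compound 1 to compound 4 (0.20 log units; within the scatter), shows that a group with two aromatic rings and no fluorine performs on a par with 4-(trifluoromethyl)phenyl, so among these four compounds fluorine is not needed on this group for a number to be read, while compound 2 and compound 3 show that fluorine alone does not secure one.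

As far as these compounds go, what stays open is whether a plain phenyl, a naphthalen-2-yl or a pyridine ring on this oxygen would fall in the same weak region. From the compounds shown here alone, it is equally open whether an amine or a carboxylic acid on the naphthalene rings would move the number well beyond what compound 1 and compound 4 reach.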